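Methoxy for methyl on two related cores

The source may hold more compounds than are shown below. What is called first, only, known or untested is meant among the compounds shown, and "the series" means these compounds.

Measured in a physicochemical assay for permeability, using PAMPA, at pH 7.4; on this read-out higher numbers stand for higher permeability and lower numbers for lower permeability:
compound 1 `Cc1ccc2c(NCc3ccco3)nc(NC(C)C)nc2c1` gives 798 10^-6 cm/s
compound 2 `Cc1ccc2nc(NC(C)C)nc(NCc3ccco3)c2c1` gives 789 10^-6 cm/s
compound 3 `COc1ccc2c(NCc3ccco3)nc(NC(C)C)nc2c1` gives 1330 10^-6 cm/s

Compound 1 and compound 3 share one core; their single difference is methoxy in place of methyl on an aromatic carbon and the step in this assay is a 1.7-fold higher number from compound 1 to compound 3 (0.22 log units; within the scatter). Compound 2 has the same atoms as compound 1 joined differently; the difference between the two cores is not broken down here. In this assay the values of compound 1 and compound 2 lie within the scatter of each other, so nothing separates them.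

Compound 4 `COc1ccc2nc(NC(C)C)nc(NCc3ccco3)c2c1` is not yet measured. It differs from compound 2 by methoxy in place of methyl on an aromatic carbon, the same change as from compound 1 to compound 3, at a place described in the same words for both pairs. Among the compounds with values here, only this one prior instance exists, and its step is within the scatter, so the basis is thin. Still, because a 1.7-fold higher number from compound 1 to compound 3 (0.22 log units; within the scatter) was seen on the other core, a step of about a 1.6-fold higher number from compound 2 to compound 4 (0.22 log units; within the scatter) is expected here. In this assay compound 4 is thus estimated at 1300 10^-6 cm/s, with the expected range running from 850 10^-6 cm/s to 1950 10^-6 cm/s.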

Compound 4, apparent permeability: 1010 10^-6 cm/s
Compound 4: the middle estimate sits 1.3-fold (0.11 log units) above what was measured; measured number inside the range.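

In this assay the second instance of methoxy in place of methyl on an aromatic carbon gives a 1.3-fold higher number from compound 2 to compound 4 (0.11 log units; within the scatter) and the first gave a 1.7-fold higher number from compound 1 to compound 3 (0.22 log units; within the scatter) on the other core. Both steps lie within the scatter, so the two cores agree only in that neither shows a step that can be told apart from repeat measurements; this does not show that the change moves the read-out on either core, nor that a step of a given size carries reliably from one core to the other. Nothing available bears on why the steps come out as they do.

Open, going by these compounds, is whether a different group at this place, such as an amine, a carboxylic acid or a longer chain, would give a step beyond the scatter on either core, and whether that step would then carry between the two cores. Within the data shown here, with only two cores in view, nothing can be said of how this change behaves on a third.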